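Swapping the amino acid group on a shared core

A few compounds are considered here, and "the series" means these few. Any claim that something is new, unique, unknown or untested is made for them only; others in the source may bear on it.

In a functional assay on HeLa cells (Homo sapiens) for cytotoxicity, read by MTT assay, with a stated time of 72 h (a lower number here means a stronger inhibitor, a higher number a weaker inhibitor), three compounds gave these values:
compound 1 `CC1=CCC[C@H]2[C@](C)(CC3=CC(=O)C=C(N[C@@H](CC(C)C)C(=O)O)C3=O)[C@@H](C)CC[C@]12C` gives 7720 nM
compound 2 `CSCC[C@H](NC1=CC(=O)C=C(C[C@]2(C)[C@@H](C)CC[C@]3(C)C(C)=CCC[C@@H]23)C1=O)C(=O)O` gives 13900 nM
compound 3 `CC1=CCC[C@H]2[C@](C)(CC3=CC(=O)C=C(N[C@@H](C(=O)O)C(C)C)C3=O)[C@@H](C)CC[C@]12C` gives 10900 nM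

The steps of a 1.4-fold higher number from compound 1 to compound 3 (0.15 log units; within the scatter) and a 1.3-fold lower number from compound 2 to compound 3 (0.11 log units; within the scatter) place compound 3 within the scatter of both others. The change to compound 4 `CC1=CCC[C@H]2[C@](C)(CC3=CC(=O)C=C(N[C@@H](C)C(=O)O)C3=O)[C@@H](C)CC[C@]12C` is 1-carboxyethyl in place of 1-carboxy-2-methylpropyl on an amine nitrogen and reads 1-carboxyethyl in place of 1-carboxy-2-methylpropyl on an amine nitrogen. Those two steps and a 1.8-fold higher number from compound 1 to compound 2 (0.26 log units; within the scatter) bear on it, as each alters the group on that nitrogen. Going by the values given here, none of the measured compounds carries 1-carboxyethyl. No step beyond the scatter is therefore expected in this assay for this change. The estimated step is a 1.0-fold lower number from compound 3 to compound 4 (0.02 log units; within the scatter) and is expected to stay within the scatter. Compound 4 is estimated at 10500 nM with an expected range from 5500 nM to 20000 nM at its upper end.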

Compound 4, half-maximal inhibitory concentration: 11700 nM
Compound 4: middle estimate off by 1.1-fold (0.05 log units), on the low side, and the stated range covers the measured number.
By their numbers in this assay, from the lowest: compounds 1, 3, 4 and 2 (each within the scatter of the next).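

In this assay the 1-carboxyethyl group gives a 1.1-fold higher number from compound 3 to compound 4 (0.03 log units; within the scatter) and, against the other two groups on the amine nitrogen, a 1.2-fold lower number from compound 2 to compound 4 (0.07 log units; within the scatter) and a 1.5-fold higher number from compound 1 to compound 4 (0.18 log units; within the scatter), all within the scatter. Compound 4 therefore shows that shortening the side chain to 1-carboxyethyl, like the earlier swaps among larger groups, produces no step beyond the scatter at this position. Nothing available explains this result. The compounds shown leave open whether a side chain ending in an amine, a second carboxylic acid or a phenyl ring would move the number beyond the scatter. They also leave open what happens when the carboxylic acid on this chain is replaced by a methyl ester or an amide.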